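A few compounds are considered here, and "the series" means these few. Any claim that something is new, unique, unknown or untested is made for them only; others in the source may bear on it.

Within the data shown here, in an ADME assay on BaF3 cells (Mus musculus) for antiproliferative activity, read by CCK-8 assay, with a stated time of 72 h (a lower number here means a stronger inhibitor of growth, a higher number a weaker inhibitor of growth), compound 2 `O=C(CCSc1ccc2c(/C=C/c3ccccn3)n[nH]c2c1)NCc1cccc(C(F)(F)F)c1` gives 8030 nM, the only actual number so far. Compound 1 `Cc1ccc(NC(=O)CCSc2ccc3c(/C=C/c4ccccn4)n[nH]c3c2)cc1` reads > 10000 nM, which is a limit of the assay and not a number. Compound 3 `O=C(CCSc1ccc2c(/C=C/c3ccccn3)n[nH]c2c1)Nc1ccc(Cl)c(C(F)(F)F)c1` has 4-chloro-3-(trifluoromethyl)phenyl in place of 3-(trifluoromethyl)benzyl on the amide-type nitrogen: 4-chloro-3-(trifluoromethyl)phenyl in place of 3-(trifluoromethyl)benzyl on an amide-type nitrogen. Among the measured compounds shown here, only one measured step bears on this change, an at least 1.2-fold lower number from compound 1 to compound 2 (0.09 log units; that floor lies within the scatter), and it swaps a group at the same place. With so little to go on, the expected step is a 1.3-fold lower number from compound 2 to compound 3 (0.13 log units; within the scatter), with none beyond the scatter anticipated. Compound 3 is estimated at 6000 nM, with an expected range of 1200 nM to 10000 nM.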

Compound 3, concentration for 50% growth inhibition: > 10000 nM
Compound 3: only a limit was reported (the forecaster's own chance of this, stated with the estimate: 35%); middle value at least 1.6-fold (0.22 log units) from the limit.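

In this assay, 4-chloro-3-(trifluoromethyl)phenyl on the amide-type nitrogen gives an at least 1.2-fold higher number from compound 2 to compound 3 (0.09 log units; that floor lies within the scatter), so nothing here reads as a gain over 3-(trifluoromethyl)benzyl, though the floor of that step cannot separate the two groups. The steps to and from compound 1 cannot be read, since compound 1 and compound 3 both stand at a limit. Little can therefore be compared at this position, and the readings stop at: the limit of > 10000 nM in this assay, at which 2 of the 3 values shown sit.

On these data alone, it remains open whether a 4-chloro-3-(trifluoromethyl)benzyl or a phenethyl group on this nitrogen would give a number clear of that limit.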